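The compounds below may be only part of what the source reports. "The series", "measured", "known", "first", "only" and "open" are said of these compounds alone.

- Compound 1 `CC1=CCC[C@H]2[C@](C)(CC3=CC(=O)C=CC3=O)[C@@H](C)CC[C@]12C`: 17100 nM
- Compound 2 `CC1=CCC[C@H]2[C@](C)(CC3=CC(=O)C=C(N[C@@H](CC(C)C)C(=O)O)C3=O)[C@@H](C)CC[C@]12C`: 11200 nM

In a functional assay on K562 cells (Homo sapiens) for cytotoxicity, read by MTT assay, with a stated time of 72 h (a lower number here means a stronger inhibitor, a higher number a weaker inhibitor), compound 2 gives 11200 nM, which lies within the scatter of the value for compound 1. Compound 3 `CSCC[C@H](NC1=CC(=O)C=C(C[C@]2(C)[C@@H](C)CC[C@]3(C)C(C)=CCC[C@@H]23)C1=O)C(=O)O` carries one change from compound 2, on a saturated chain carbon: (methylsulfanyl)methyl in place of isopropyl on a saturated chain carbon, two bonds along the chain from an amine nitrogen and a carbonyl carbon. Going by the values given here, only one measured step bears on this, a 1.5-fold lower number from compound 1 to compound 2 (0.18 log units; within the scatter). Adding the whole amino acid-derived group there moved the number no further than the scatter, so swapping isobutyl for 2-(methylsulfanyl)ethyl is expected to do no more. The expected change is a 1.0-fold lower number from compound 2 to compound 3 (0.01 log units; within the scatter). For compound 3 the estimated value is 11000 nM, with an expected range of 5500 nM to 22000 nM.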

Compound 3, half-maximal inhibitory concentration: 13600 nM
Estimate against measurement, compound 3: 1.2-fold (0.09 log units) below, within the range that was stated.
By their numbers in this assay, from the lowest: compounds 2, 3 and 1 (each within the scatter of the next).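

In this assay, putting (methylsulfanyl)methyl in place of isopropyl on this saturated chain carbon gives a 1.2-fold higher number from compound 2 to compound 3 (0.08 log units; within the scatter) and stays within the scatter, so a sulfur can enter this side chain with no readable change. Measured against the bare core, the whole (1-carboxy-3-(methylsulfanyl)propyl)amino group gives a 1.3-fold lower number from compound 1 to compound 3 (0.10 log units; within the scatter) and also stays within the scatter. Nothing measured here explains why these numbers stay so close. Still open, from the compounds shown here alone, is whether an amine, a phenyl ring or a longer chain at this carbon would move the number beyond the scatter.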